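The source may hold more compounds than are shown below. What is called first, only, known or untested is meant among the compounds shown, and "the series" means these compounds.

Compound 2 `CC[C@@H](c1nc2ccc(C(=O)O)cc2n1C)N1C(=O)CN(c2ccc(Oc3ccccc3)cc2)C1=O`: 210000 nM
Compound 1 `CC(C)C[C@@H](c1nc2ccc(C(=O)O)cc2n1C)N1C(=O)CN(c2cccc(Oc3ccccc3)c2)C1=O`: 18200 nM
Compound 3 `Cc1ccc2nc([C@H](CC3CCCCC3)N3C(=O)CN(c4ccc(Oc5ccccc5)cc4)C3=O)n(C)c2c1`: 126000 nM

In an assay on isolated protein for inhibition of Bile acid receptor (Homo sapiens), read by TR-FRET and LanthaScreen (on this read-out lower numbers stand for stronger inhibition and higher numbers for weaker inhibition), compound 2 gives the highest of the three numbers. Compound 3 stands nearest, within the scatter, so no order between compound 2 and compound 3 can be read. Compound 1 stands furthest, beyond the scatter.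

Compound 4 `CC(C)C[C@@H](c1nc2ccc(C(=O)O)cc2n1C)N1C(=O)CN(c2ccc(Oc3ccccc3)cc2)C1=O` differs from compound 2 by isopropyl in place of methyl on a saturated chain carbon, two bonds along the chain from an amide-type nitrogen in a ring and an aromatic carbon. Going by the values given here, no measured pair shows this change alone. Compound 1, which also carries the isobutyl chain, gives the lowest number of the three in this assay, and that is taken as the guide. The step from compound 2 to compound 4 is expected to be a 5.3-fold lower number from compound 2 to compound 4 (0.72 log units; beyond the scatter), beyond the scatter and toward a lower number. Compound 4 is estimated at 40000 nM, within 10000 nM to 150000 nM.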

Compound 4, half-maximal inhibitory concentration: 43400 nM
Compound 4: middle estimate off by 1.1-fold (0.04 log units), on the low side; the range from low to high includes it.
By their numbers in this assay, from the lowest: compound 1; then compound 4; then compounds 3 and 2 (each within the scatter of the next).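

In this assay, going by these compounds alone, ethyl to isobutyl at this saturated chain carbon gives a 4.8-fold lower number from compound 2 to compound 4 (0.68 log units; beyond the scatter), the first single-change comparison and evidence that this position responds to the chain. The change alone does not reach the lowest number: compound 4 gives 43400 nM, while compound 1 gives 18200 nM. No measurement here accounts for the step. Still open, from the compounds shown here alone, is how a longer straight chain or a chain ending in an amine would read at this position.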